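The compounds below may be only part of what the source reports. "The series", "measured", "known", "first", "only" and "open" are said of these compounds alone.

Measured compounds:
compound 1, `COc1cc(/C=C2\CN(C)C/C(=C\c3ccncc3)C2=O)cc(OC)c1OC`, gives 5900 nM
compound 2, `Cc1ccc(S(=O)(=O)N2C/C(=C\c3cccnc3)C(=O)/C(=C/c3ccccc3F)C2)cc1`, gives 9700 nM

Both compounds were tested in a functional assay on QGY-7703 cells (Homo sapiens) for cytotoxicity, read by MTT assay, with a stated time of 24 h; on this read-out lower numbers stand for stronger inhibition and higher numbers for weaker inhibition. Of the two numbers shown, compound 2 has the higher one, and the only neighbour is compound 1, whose number is lower by an amount that stays within the usual scatter of repeated measurements, so no order between these two can be claimed. Within the data shown here, no pair of measured compounds that differ in only one place is available, so nothing is yet known about how small changes move this read-out.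

Compound 3, `N#Cc1ccc(S(=O)(=O)N2C/C(=C\c3cccnc3)C(=O)/C(=C/c3ccccc3F)C2)cc1`, is the next compound to be measured. It is built from compound 2 by the change (cyano in place of methyl on an aromatic carbon). Among the measured compounds shown here, since no measured step of this kind exists here, the expectation rests on compound 2 alone: its value of 9700 nM is taken as the anchor, and the step from compound 2 to compound 3 is expected to be a 1.1-fold lower number from compound 2 to compound 3 (0.03 log units; within the scatter), which is no change beyond the scatter. For compound 3 the estimate in this assay is 9000 nM, with an expected range from 3000 nM to 27000 nM.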

Compound 3, half-maximal inhibitory concentration: 15800 nM
Estimate against measurement, compound 3: 1.8-fold (0.24 log units) below; low and high end bracket the measured number.
By their numbers in this assay, from the lowest: compounds 1, 2 and 3 (each within the scatter of the next, the first and the last beyond it).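

In this assay, cyano in place of methyl on an aromatic carbon, para to a large group, gives a 1.6-fold higher number from compound 2 to compound 3 (0.21 log units; within the scatter). Among these compounds, this is the first step that differs in one place, and it gives a first reading of how this position responds: going from 4-methylphenyl to 4-cyanophenyl swaps a group of one heavy atom for a group of two heavy atoms that adds a hydrogen-bond acceptor, yet the change cannot be told apart from the variation between repeated measurements. No measurement at hand bears on this result or offers an explanation for it.

A single step at one position cannot show whether this aromatic carbon accepts changes in general, and an amine or a carboxylic acid here might read quite differently from methyl and cyano. As far as these compounds go, it also remains open whether the same swap would behave alike in a compound that differs elsewhere, such as one with another group in place of the 2-fluorophenyl ring of compound 2.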